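This account rests on a few compounds, and the source may have more. Where it says the series, first, only, none or still open, it means among the compounds named here.

Measured in a functional assay on NCI/ADR-RES cells (Homo sapiens) for antiproliferative activity; on this read-out higher numbers stand for weaker inhibition of growth and lower numbers for stronger inhibition of growth:
- compound 1 `CC/C=C\[C@H](C)[C@H](OC(N)=O)[C@@H](C)[C@H](O)[C@@H](C)C/C(C)=C\[C@H](C)[C@@H](O)[C@@H](C)/C=C\[C@@H](O)C[C@H]1CCC(=O)O1`: 730 nM
- compound 2 `CC/C=C\[C@H](C)[C@H](OC(N)=O)[C@@H](C)[C@H](O)[C@@H](C)C/C(C)=C\[C@H](C)[C@@H](O)[C@@H](C)/C=C\[C@@H](O)C[C@H](O)[C@H](C)C[C@H](C)C(=O)OC`: 10000 nM

Compound 2 stands highest of the two. For the measured compounds named here, the only measured step, a 14-fold higher number from compound 1 to compound 2 (1.14 log units; beyond the scatter), replaced a group with one five-membered non-aromatic ring by a group with no ring. Compound 3 `CC/C=C\[C@H](C)[C@H](OC(N)=O)[C@@H](C)[C@H](O)[C@@H](C)C/C(C)=C\[C@H](C)[C@@H](O)[C@@H](C)/C=C\[C@@H](O)C[C@@H]1OC(=O)NC[C@H]1C` differs from compound 2 thus: a group of 8 heavy atoms (5 carbon, 1 nitrogen, 2 oxygen; one six-membered non-aromatic ring with 2 hetero atoms) in place of a group of 11 heavy atoms (8 carbon, 3 oxygen; no ring), on a saturated chain carbon, two bonds along the chain from a double-bonded chain carbon and an oxygen on a saturated carbon. A ring returns, but it is six-membered with 2 hetero atoms, so that step is only a rough guide. A lower number is expected in this assay, though probably by less than the measured step. The expected change is a 5.0-fold lower number from compound 2 to compound 3 (0.70 log units; beyond the scatter). Compound 3 is estimated at 2000 nM, with an expected range of 400 nM to 8000 nM.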

Compound 3, concentration for 50% growth inhibition: 10000 nM
Compound 3: middle estimate off by 5.0-fold (0.70 log units), on the low side; the measured number lies above the stated range.
By their numbers in this assay, from the lowest: compound 1; then compounds 2 and 3 (each within the scatter of the next).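

Having a ring at this position is not enough in this assay: the six-membered ring with 2 hetero atoms gives no change at the digits printed from compound 2 to compound 3 (within the scatter) against the open chain. Set against the five-membered ring with 1 hetero atom, that same ring gives a 14-fold higher number from compound 1 to compound 3 (1.14 log units; beyond the scatter), so among these three compounds only compound 1 stands apart. Ring size and the ring nitrogen change together here, and a six-membered lactone at this position would be needed to separate them. Nothing available explains why these rings differ.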